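Adding a second chloro group to compound 2

The source may hold more compounds than are shown below. What is called first, only, known or untested is meant among the compounds shown, and "the series" means these compounds.

Compound 1 `Cc1ccc(S(=O)(=O)N/C(=N\O)Nc2ccc(Cl)c(Cl)c2)cc1` gives 67 ug/mL
Compound 2 `Cc1ccc(S(=O)(=O)/N=C(\S)Nc2ccc(Cl)cc2)cc1` gives 125 ug/mL

In a functional assay on TSGH 8302 cells (Homo sapiens) for cytotoxicity (on this read-out higher numbers stand for weaker inhibition and lower numbers for stronger inhibition), compound 2 gives 125 ug/mL and lies within the scatter of compound 1 at 67 ug/mL so the two cannot be ranked. Compound 3 `Cc1ccc(S(=O)(=O)/N=C(\S)Nc2ccc(Cl)c(Cl)c2)cc1` differs from compound 2 by one change (chloro in place of hydrogen on an aromatic carbon) with chloro in place of hydrogen on an aromatic carbon, ortho to a chloro group. Within the data shown here, no measured pair shows this change alone. In this assay only a small move toward stronger inhibition is expected, nothing beyond the scatter. The estimate amounts to an expected step (a 1.5-fold lower number from compound 2 to compound 3 (0.17 log units; within the scatter)) of that size. Compound 3 is expected at 85 ug/mL (estimated range 35 ug/mL to 190 ug/mL).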

Compound 3, half-maximal inhibitory concentration: 55 ug/mL
The estimate for compound 3 lay 1.5-fold (0.19 log units) above the measured number, within the range that was stated.
By their numbers in this assay, from the lowest: compounds 3, 1 and 2 (each within the scatter of the next, the first and the last beyond it).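

In this assay this position proves responsive: chloro in place of hydrogen on an aromatic carbon, ortho to a chloro group, gives a 2.3-fold lower number from compound 2 to compound 3 (0.36 log units; beyond the scatter) and so a modest step. The earlier compounds shown here, which differ in more than one place, could not show this. Nothing measured here explains the step. The compounds shown leave open whether a fluoro, a methyl or a methoxy group at this position would give a step of similar size, and whether an amine there would reverse it.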